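This account rests on a few compounds, and the source may have more. Where it says the series, first, only, none or still open, it means among the compounds named here.

Three compounds share one core and differ only in the group on a ring nitrogen. Compound 1 `c1ccc(-c2nc[nH]n2)c(NCC2=NCCN2)c1` carries a hydrogen there; in an in vitro functional assay on cells (Fibroblast) for agonist activity at Alpha-1A adrenergic receptor (Homo sapiens) (on this read-out lower numbers stand for an effect already at smaller amounts and higher numbers for an effect only at larger amounts of compound), compound 1 gives 0.794 nM. Compound 2 `CCn1ncnc1-c1ccccc1NCC1=NCCN1` carries an ethyl, and in this assay compound 2 gives 1.26 nM, the second highest of the three numbers, with its gap to compound 1 lying within the scatter. Compound 3 `CCCCn1ncnc1-c1ccccc1NCC1=NCCN1` carries a butyl, and compound 3 gives 200 nM. Among the compounds with values here, the only measured step that bears on the new compound is a 160-fold higher number from compound 2 to compound 3 (2.20 log units; beyond the scatter), a large loss on lengthening the chain.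

Compound 4 `CC(C)n1ncnc1-c1ccccc1NCC1=NCCN1` has not been measured. It differs from compound 2 by methyl in place of hydrogen on a saturated chain carbon bound to an aromatic nitrogen and a saturated chain carbon. The ethyl of compound 2 thus grows again, but by branching at the carbon bound to the ring rather than by lengthening the chain. Whether branching costs as much as lengthening cannot be read from these three compounds, so the direction of a loss is expected but its size is open.

Compound 4 is expected to give 12 nM in this assay, somewhere between 2 nM and 80 nM. That estimate means an expected step of a 9.5-fold higher number from compound 2 to compound 4 (0.98 log units; beyond the scatter), smaller than the measured loss from lengthening but clearly beyond the scatter.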

Compound 4, half-maximal effective concentration: 6.31 nM
Compound 4: the middle estimate sits 1.9-fold (0.28 log units) above what was measured, within the range that was stated.
By their numbers in this assay, from the lowest: compounds 1 and 2 (each within the scatter of the next); then compound 4; then compound 3.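

In this assay, adding one methyl to the carbon bound to the aromatic nitrogen, which turns ethyl into isopropyl, gives a 5.0-fold higher number from compound 2 to compound 4 (0.70 log units; beyond the scatter), so even this small branch at this position moves the number beyond the scatter. Putting isopropyl in place of butyl gives a 32-fold lower number from compound 3 to compound 4 (1.50 log units; beyond the scatter), which shows that the group on this nitrogen can grow at a far smaller cost as an isopropyl than as a butyl, although the two groups differ in both branching and size. Nothing shown here gives a measured reason for either step.

A straight propyl chain on the same nitrogen would help separate the effect of branching from that of added chain length, since the comparison of isopropyl with butyl changes both at once. From the compounds shown here alone, it also remains open whether the number would keep rising with further branching, as in a tert-butyl group, or how a cyclopropyl group, whose carbons are tied back into a small ring, would compare with the isopropyl of compound 4.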